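Lengthening the chain that carries a piperazine

A few compounds are considered here, and "the series" means these few. Any claim that something is new, unique, unknown or untested is made for them only; others in the source may bear on it.

Compound 1 `c1ccc2c(c1)CN[C@@H](CN(CC[C@@H]1CCCNC1)[C@H]1CCCc3cccnc31)C2` gives 75%
Compound 2 `c1ccc2c(c1)CN[C@@H](CN(CCC1CCNCC1)[C@H]1CCCc3cccnc31)C2` gives 66%
Compound 3 `c1ccc2c(c1)CN[C@@H](CN(CCN1CCNCC1)[C@H]1CCCc3cccnc31)C2` gives 96%

In an ADME assay on microsomes from liver (Homo sapiens) for metabolic stability, read by LC-MS, with a stated time of 10 min, tested at 0.5 uM (a higher number here means that more of the compound is left, a lower number that less of the compound is left), compound 3 gives 96% as the highest of the three numbers, clearly ahead of both other compounds. The step to compound 4 `c1ccc2c(c1)CN[C@@H](CN(CCCCN1CCNCC1)[C@H]1CCCc3cccnc31)C2` is this one: 2-(piperazin-1-yl)ethyl in place of piperazin-1-yl on a saturated chain carbon, two bonds along the chain from an amine nitrogen and so 2-(piperazin-1-yl)ethyl stands in place of piperazin-1-yl on a saturated chain carbon, two bonds along the chain from an amine nitrogen.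

Two measured steps changed the group at this same place and ended at compound 3: a number 21 percentage points higher from compound 1 to compound 3 (beyond the scatter) and also a number 30 percentage points higher from compound 2 to compound 3 (beyond the scatter) while a third, a number 9 percentage points lower from compound 1 to compound 2 (within the scatter), swapped one piperidine attachment for another. None of them lengthens a chain, so they show only how far a change here has moved the number. With compound 3 at 96% little room remains upward, so a modest step down is the likelier outcome. The expected step is a number 16 percentage points lower from compound 3 to compound 4 (beyond the scatter) and this is an estimate only. For compound 4 the estimated value is 80% with 60% to 97% as its expected range.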

Compound 4, percent of the compound remaining: 82%
The estimate for compound 4 lay 2 percentage points below the measured number; the measured number falls inside the stated range.
By their numbers in this assay, from the lowest: compounds 2, 1 and 4 (each within the scatter of the next, the first and the last beyond it); then compound 3.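

In this assay, carrying the piperazine further out on the chain, with 2-(piperazin-1-yl)ethyl in place of piperazin-1-yl, gives a lower number (a number 14 percentage points lower from compound 3 to compound 4 (beyond the scatter)), so keeping the piperazine ring does not by itself keep the number at the top, and the length of the link at this place matters as well. Set against the piperidine compounds, the longer group gives two different readings: it stands clearly apart from piperidin-4-yl (a number 16 percentage points higher from compound 2 to compound 4 (beyond the scatter)) but not from piperidin-3-yl (a number 7 percentage points higher from compound 1 to compound 4 (within the scatter)). No measurement shown here accounts for these differences.

The compounds shown leave open whether a longer chain would lower the number further. They also leave open whether a morpholine at the end of the same chain would read like the piperazine.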